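Methyl for hydrogen on two cores in a cytotoxicity assay

The source may hold more compounds than are shown below. What is called first, only, known or untested is meant among the compounds shown, and "the series" means these compounds.

Compound 1 `COc1ccc(C(=O)CSc2nc(CC3CCCCC3)c(C(C)C)c(=O)[nH]2)cc1` and compound 2 `CCc1c(CC2CCCCC2)nc(SCC(=O)c2ccc(OC)cc2)[nH]c1=O` were examined in an ADME assay on C1866 cells (Homo sapiens) for cytotoxicity, read by MTT assay, with a stated time of 72 h; a higher number here means that more compound is needed for the effect, a lower number that less compound is needed. Compound 1 gives 0.162 nM and compound 2 gives 0.217 nM. The change between them, (methyl in place of hydrogen on a saturated chain carbon bound to an aromatic carbon and a saturated chain carbon), made a step of a 1.3-fold lower number from compound 2 to compound 1 (0.13 log units; within the scatter). Compound 3 `CCc1c(Cc2ccccc2)nc(SCC(=O)c2ccccc2)[nH]c1=O` stands apart: in this assay compound 3 gives 80.2 nM, far higher than either of the other two. The difference between the core of compound 3 and the core of compound 2 is not broken down here. Compound 4 `CC(C)c1c(Cc2ccccc2)nc(SCC(=O)c2ccccc2)[nH]c1=O` differs from compound 3 by methyl in place of hydrogen on a saturated chain carbon bound to an aromatic carbon and a saturated chain carbon, the same kind of change, at the same place as described, as that from compound 2 to compound 1. Since that earlier step was within the scatter, compound 4 is expected to show a step of a 1.2-fold lower number from compound 3 to compound 4 (0.09 log units; within the scatter) in this assay. Compound 4 is therefore estimated at 65 nM, with a likely range from 25 nM to 200 nM.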

Compound 4, half-maximal effective concentration: 14 nM
Compound 4: middle estimate off by 4.6-fold (0.67 log units), on the high side; the measured number lies below the stated range.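

Carried to the second core, methyl in place of hydrogen gave a 5.7-fold lower number from compound 3 to compound 4 (0.76 log units; beyond the scatter) in this assay. The size of the step did not carry over from one core to the other: the same change on two cores in this assay, a 1.3-fold lower number (0.13 log units; within the scatter) from compound 2 to compound 1 and a 5.7-fold lower number (0.76 log units; beyond the scatter) from compound 3 to compound 4, 4.3-fold (0.63 log units) apart, beyond the scatter of two such steps. Within the data shown here, with only two pairs, this shows that the step cannot simply be transferred between these cores, but it does not show which difference between the cores goes with the gap, nor what a third core would give.

The compounds shown leave open what a longer chain, such as propyl, or a cyclopropyl ring would give in place of the methyl in this assay. They also leave open whether the larger or the smaller step is the more usual one in this series.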